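Enantiomer of compound 2 in the ABHD6 assay

A few compounds are considered here, and "the series" means these few. Any claim that something is new, unique, unknown or untested is made for them only; others in the source may bear on it.

Measured compounds: compound 1 `O=C(N1CCCC[C@@H]1COCc1ccccc1)n1cc(-c2ccc(-c3ccccc3)cc2)nn1` with 3.16 nM; compound 2 `O=C(N1CCC=C[C@@H]1Cc1ccccc1)n1cc(-c2ccc(-c3ccccc3)cc2)nn1` with 2.51 nM.

In an assay on HEK293 cells for inhibition of Monoacylglycerol lipase ABHD6 (Homo sapiens), read by fluorescence (on this read-out higher numbers stand for weaker inhibition and lower numbers for stronger inhibition), compound 2 gives 2.51 nM, the lowest of the two numbers, with compound 1 at 3.16 nM within the scatter of it. Compound 3 `O=C(N1CCC=C[C@H]1Cc1ccccc1)n1cc(-c2ccc(-c3ccccc3)cc2)nn1` differs from compound 2 in one way: the two compounds have the same atoms and bonds and differ only in configuration as drawn: 1 of 1 stereo elements differ; a stereocentre at a saturated ring carbon is drawn S in compound 2 and R in compound 3. Within the data shown here, no measured pair shows what a change of configuration does here, so the direction is open. Compound 3 is estimated at 8 nM, between 1.5 nM and 60 nM, which means an expected step of a 3.2-fold higher number from compound 2 to compound 3 (0.50 log units; beyond the scatter) in this assay, beyond the scatter but with a wide margin either way.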

Compound 3, half-maximal inhibitory concentration: 25.1 nM
Estimate against measurement, compound 3: 3.1-fold (0.50 log units) below, and the stated range covers the measured number.
By their numbers in this assay, from the lowest: compounds 2 and 1 (each within the scatter of the next); then compound 3.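

The configuration at this saturated ring carbon matters: in this assay, moving from S to R gives a 10-fold higher number from compound 2 to compound 3 (1.00 log units; beyond the scatter). Among these compounds, this is the first step that can be read, and compounds 1 and 2 alone could not show that this position is sensitive to configuration. The step can be assigned to this stereocentre alone because nothing else separates the pair: the fact that compounds 2 and 3 differ only in the configuration as drawn

The compounds shown rest on one pair, so it remains open whether the preference for S would hold in the series of compound 1. As far as these compounds go, it is also open whether that preference would survive if an amine or a carboxylic acid were carried on the substituent at this stereocentre.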